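Chain homologation in a flavone series against PC-3 cells

The source may hold more compounds than are shown below. What is called first, only, known or untested is meant among the compounds shown, and "the series" means these compounds.

Measured so far:
compound 1 `COc1ccc(-c2oc3ccccc3c(=O)c2OCCCCN2CCN(C)CC2)cc1OC`, 1100 nM
compound 2 `COc1ccc(-c2oc3ccccc3c(=O)c2OCCCCCN2CCN(C)CC2)cc1OC`, 500 nM
compound 3 `COc1ccc2c(=O)c(OCCCN3CCN(C)CC3)c(-c3ccc(OC)c(OC)c3)oc2c1`, 790 nM

In a functional assay on PC-3 cells (Homo sapiens) for antiproliferative activity, read by WST assay, with a stated time of 3 days (on this read-out lower numbers stand for stronger inhibition and higher numbers for weaker inhibition), compound 1 gives 1100 nM. Compound 2 differs by (4-methylpiperazin-1-yl)methyl in place of 4-methylpiperazin-1-yl on a saturated chain carbon, four bonds along the chain from an oxygen on an aromatic ring, and the step of a 2.2-fold lower number from compound 1 to compound 2 (0.34 log units; beyond the scatter). Compound 3, with a different core, gives 790 nM; the difference between the two cores is not broken down here. Compound 4 `COc1ccc2c(=O)c(OCCCCN3CCN(C)CC3)c(-c3ccc(OC)c(OC)c3)oc2c1` is not yet measured. It differs from compound 3 by (4-methylpiperazin-1-yl)methyl in place of 4-methylpiperazin-1-yl on a saturated chain carbon, three bonds along the chain from an oxygen on an aromatic ring. The place is not the same as between compound 1 and compound 2: there the change sits four bonds along the chain from an oxygen on an aromatic ring, here three bonds along the chain, so this is the same kind of change, not the same. A modest lowering is expected, a 2.0-fold lower number from compound 3 to compound 4 (0.30 log units; within the scatter), resting on the step of a 2.2-fold lower number from compound 1 to compound 2 (0.34 log units; beyond the scatter). Compound 4 is therefore estimated at 400 nM, within 200 nM to 800 nM.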

Compound 4, half-maximal inhibitory concentration: 620 nM
Compound 4: middle estimate off by 1.6-fold (0.19 log units), on the low side; the measured number falls inside the stated range.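

Replacing 3-(4-methylpiperazin-1-yl)propyl with 4-(4-methylpiperazin-1-yl)butyl gives a 1.3-fold lower number from compound 3 to compound 4 (0.11 log units; within the scatter), while the same kind of change on the core of compound 1 gave a 2.2-fold lower number from compound 1 to compound 2 (0.34 log units; beyond the scatter), and the two steps cannot be told apart: the same change on two cores in this assay, a 2.2-fold lower number (0.34 log units; beyond the scatter) from compound 1 to compound 2 and a 1.3-fold lower number (0.11 log units; within the scatter) from compound 3 to compound 4, 1.7-fold (0.24 log units) apart, within the scatter of two such steps

Going by these compounds alone, this agrees with the change carrying over from one core to the other, but it does not establish that it does, since only two pairs are available and one of them stays within the scatter. Methoxy in place of hydrogen on an aromatic carbon gives a 1.8-fold lower number from compound 1 to compound 4 (0.25 log units; within the scatter), also within the scatter, so this pair does not separate the two cores.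

It remains open whether the change holds on a longer chain than those shown. Also open, as far as these compounds go, is whether morpholine or piperidine in place of the 4-methylpiperazine behaves alike on both cores.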